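A few compounds are considered here, and "the series" means these few. Any claim that something is new, unique, unknown or untested is made for them only; others in the source may bear on it.

Three compounds sharing one core are compared in a functional assay on PC-3 cells (Homo sapiens) for cytotoxicity, read by sulforhodamine B assay, with a stated time of 48 h; a lower number here means a stronger inhibitor, a higher number a weaker inhibitor. Compound 1 `C=CCOc1cc(Br)ccc1C(=O)c1cccnc1` gives only a limit of the assay, > 100000 nM, which is the limit of > 100000 nM in this assay, at which 1 of the 3 values shown sits. Compound 2 `O=C(c1cccnc1)c1ccccc1O` gives 33400 nM. Compound 3 `C=CCOc1ccc(C)cc1C(=O)c1cccnc1` gives 98000 nM, the higher of the two numbers, and its nearest neighbour is compound 2, which sits beyond the scatter from it. Compound 4 `C=CCOc1ccccc1C(=O)c1cccnc1` differs from compound 3 in one place: hydrogen in place of methyl on an aromatic carbon. Within the data shown here, no pair of measured compounds differs in a single place, so no measured step guides this change. The expected step is a 1.1-fold lower number from compound 3 to compound 4 (0.04 log units; within the scatter), likely within the scatter. Compound 4 is accordingly estimated at 90000 nM, with a range from 35000 nM to 250000 nM.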

Compound 4, half-maximal inhibitory concentration: 55000 nM
Compound 4: the middle estimate sits 1.6-fold (0.21 log units) above what was measured, and the stated range covers the measured number.
By their numbers in this assay, from the lowest: compounds 2, 4 and 3 (each within the scatter of the next, the first and the last beyond it). At a limit, above all of these: compound 1.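

In this assay, hydrogen in place of methyl para to the allyloxy group gives a 1.8-fold lower number from compound 3 to compound 4 (0.25 log units; within the scatter), so the methyl at this position makes no difference that can be told from the scatter. Allyl in place of hydrogen on the oxygen gives a 1.6-fold higher number from compound 2 to compound 4 (0.22 log units; within the scatter), and hydrogen in place of bromo gives an at least 1.8-fold lower number from compound 1 to compound 4 (0.25 log units; that floor lies within the scatter). Compound 1 stands only at a limit, so this last step is a floor: the limit of > 100000 nM in this assay, at which 1 of the 4 values shown sits.

The compounds shown leave open whether an amine or a carboxylic acid at this position would give a step beyond the scatter. They also leave open whether a longer chain on the oxygen in place of allyl would do so.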